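Notes on a nitrile-bearing aminopyridine series against protein kinase C theta

A few compounds are considered here, and "the series" means these few. Any claim that something is new, unique, unknown or untested is made for them only; others in the source may bear on it.

Of the compounds shown here, three have been measured so far. Compound 1 `N#Cc1cnc(NCc2ccccc2C(F)(F)F)cc1N[C@H]1CC[C@H](O)CC1` gives 4000 nM in an assay on isolated protein for inhibition of protein kinase C theta type (Homo sapiens), read by TR-FRET, with a stated time of 2 h; a higher number here means a weaker inhibitor, a lower number a stronger inhibitor. Compound 2 `N#Cc1cnc(NCc2cnccc2C(F)(F)F)cc1NC[C@H]1CC[C@@H](O)CC1` gives 58 nM in this assay, and compound 3 `N#Cc1cnc(NCc2cnccc2C(F)(F)F)cc1N[C@H]1CC[C@@H](n2cncn2)CC1` gives 100 nM in this assay. Compound 2 has the lowest number of the three; its distance from compound 3 lies within the scatter, while its distance from compound 1 lies beyond it. Going by the values given here, the only change that is clearly beyond the scatter is therefore the one between compound 1 and compound 2, and these two compounds differ in more than one place, so no single cause can be read from them.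

Compound 4 `CC1(C)[C@@H](Nc2cc(NCc3cnccc3C(F)(F)F)ncc2C#N)C[C@H]1C(N)=O` has not yet been measured. It differs from compound 2 in one place: 3-carbamoyl-2,2-dimethylcyclobutyl in place of (4-hydroxycyclohexyl)methyl on a nitrogen on an aromatic ring. Among the compounds with values here, no pair of measured compounds that differ only in this way is available, so the size of this step is open. Since compound 3, which also carries a ring directly on that nitrogen, stands within the scatter of compound 2, a modest step is expected, if anything toward a higher number, and likely not beyond the scatter: the step from compound 2 to compound 4 is estimated at a 1.9-fold higher number from compound 2 to compound 4 (0.28 log units; within the scatter). Compound 4 is expected to give about 110 nM in this assay, within a range of 30 nM to 400 nM.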

Compound 4, half-maximal inhibitory concentration: 140 nM
Estimate against measurement, compound 4: 1.3-fold (0.10 log units) below; the measured number falls inside the stated range.
By their numbers in this assay, from the lowest: compounds 2, 3 and 4 (each within the scatter of the next, the first and the last beyond it); then compound 1.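

In this assay, the change at this position can now be read on its own: with the rest of the molecule held constant, placing 3-carbamoyl-2,2-dimethylcyclobutyl in place of (4-hydroxycyclohexyl)methyl on the nitrogen on an aromatic ring gives a 2.4-fold higher number from compound 2 to compound 4 (0.38 log units; beyond the scatter). This single replacement changes several features at once: a four-membered ring stands in place of a six-membered one, the ring is attached directly to the nitrogen, and a carbamoyl group and two methyl groups enter while the hydroxyl leaves, although the counts of hydrogen-bond donors and acceptors stay the same. No available measurement bears on which of these features accounts for the step.

The contributions of these features remain unseparated, and the effect of the two methyl groups could be read from the same cyclobutyl ring without them, while that of the carbamoyl group could be read from a carboxylic acid, a hydroxyl or a nitrile in its place. Going by these compounds, it also remains open whether a (3-carbamoyl-2,2-dimethylcyclobutyl)methyl group, with one carbon between ring and nitrogen, would stand closer to compound 2 or to compound 4.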